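The source may report more compounds than this note shows. Statements on the series, on what has been measured and on what is new or still open speak of the compounds shown alone.

Working notes on the series. Compound 1 `CCCC(C)n1ccc2cc(/C(C)=C/C(=O)Nc3ccccc3OCCCC(=O)O)ccc21` in an assay on Prostate gland for inhibition of steroid 5-alpha-reductase (Rattus norvegicus) (a lower number here means a stronger inhibitor, a higher number a weaker inhibitor), gives 7.8 nM. Among the compounds with values here, compound 2 `C/C(=C\C(=O)Nc1ccccc1OCCCC(=O)O)c1ccc2c(ccn2C(C)c2ccccc2)c1` gives 19 nM, the highest of the two numbers known; the step of a 2.4-fold higher number from compound 1 to compound 2 (0.39 log units; beyond the scatter) is the only measured one. Compound 3 `C/C(=C\C(=O)Nc1ccccc1OCCCC(=O)O)c1ccc2c(ccn2C(c2ccccc2)c2ccncc2)c1` differs from compound 2 by pyridin-4-yl in place of methyl on a saturated chain carbon bound to an aromatic carbon and an aromatic nitrogen. Within the data shown here, no measured step covers a second aromatic ring at the same place; the one known step there, phenyl in place of propyl, weakened inhibition modestly. A further modest weakening is therefore expected, a 1.8-fold higher number from compound 2 to compound 3 (0.27 log units; within the scatter). Compound 3 is estimated at 35 nM, with a range of 10 nM to 120 nM.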

Compound 3, half-maximal inhibitory concentration: 26 nM
Compound 3: middle estimate off by 1.3-fold (0.13 log units), on the high side; the measured number falls inside the stated range.
By their numbers in this assay, from the lowest: compound 1; then compounds 2 and 3 (each within the scatter of the next).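

In this assay, pyridin-4-yl in place of methyl on a saturated chain carbon bound to an aromatic carbon and an aromatic nitrogen gives a 1.4-fold higher number from compound 2 to compound 3 (0.14 log units; within the scatter). This carbon therefore carries a pyridin-4-yl alongside the phenyl already present in compound 2 with no change beyond the scatter, which the earlier step from propyl to phenyl could not show. No evidence at hand bears on this result.

On these data alone, whether the nitrogen of the pyridin-4-yl matters stays open, and a second phenyl in its place would settle that. As far as these compounds go, how an amine on the same carbon would read is also open.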